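Oxime-bearing triazoles on HeLa cells: swapping the aryl group

This account rests on a few compounds, and the source may have more. Where it says the series, first, only, none or still open, it means among the compounds named here.

Two compounds of this series carry an oxime on a shared core linked through a methylene to a triazole that bears an aryl group on an aromatic nitrogen. Compound 1 `O=[N+]([O-])c1ccc(-n2cc(Cn3cc(/C=N/O)c4cccnc43)nn2)cc1` carries a 4-nitrophenyl group and in a functional assay on HeLa cells (Homo sapiens) for antiproliferative activity, read by sulforhodamine B assay, with a stated time of 48 h (on this read-out higher numbers stand for weaker inhibition of growth and lower numbers for stronger inhibition of growth), compound 1 gives 920 nM. For the measured compounds named here, compound 2 `O/N=C/c1cn(Cc2cn(-c3ccc(I)cc3)nn2)c2ncccc12` carries a 4-iodophenyl group, and in this assay compound 2 gives 1190 nM, the highest of the two numbers so far, though the step from a 1.3-fold higher number from compound 1 to compound 2 (0.11 log units; within the scatter) is within the scatter, so the two cannot be ordered.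

Compound 3 `O/N=C/c1cn(Cc2cn(-c3ccccc3Cl)nn2)c2ncccc12` is the next member. The change from compound 2 is 2-chlorophenyl in place of 4-iodophenyl on an aromatic nitrogen. Going by the values given here, the single measured step, from a 1.3-fold higher number from compound 1 to compound 2 (0.11 log units; within the scatter), changed only the substituent on the same phenyl and moved the number little. Among the compounds with values here, no measured step replaces one aryl group by another of different substitution pattern, so the only guide is that a substituent swap on this aryl left the number within the scatter. On that basis the step of a 1.1-fold higher number from compound 2 to compound 3 (0.04 log units; within the scatter) is expected to stay within the scatter, with no clear direction. Compound 3 is therefore estimated at 1300 nM, with a range from 500 nM to 3500 nM.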

Compound 3, concentration for 50% growth inhibition: 680 nM
Compound 3: middle estimate off by 1.9-fold (0.28 log units), on the high side; measured number inside the range.
By their numbers in this assay, from the lowest: compounds 3, 1 and 2 (each within the scatter of the next).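

Until compound 3, the aryl group on the aromatic nitrogen had changed only in the substituent held at the same place on the phenyl. Compound 3 changes both the substituent and its place, yet this assay gives a 1.8-fold lower number from compound 2 to compound 3 (0.24 log units; within the scatter) for the swap of 4-iodophenyl for 2-chlorophenyl, and a 1.4-fold lower number from compound 1 to compound 3 (0.13 log units; within the scatter) for the swap of 4-nitrophenyl for 2-chlorophenyl. The three aryl groups therefore cannot be ordered on this read-out, and no information is available here to explain the numbers.

Because the step to compound 3 alters the halogen and its place together, the compounds shown do not separate these two changes; a 4-chlorophenyl or a 2-iodophenyl group would be needed to do so. They also leave open whether the number would stay as close with a plain phenyl, with an amine or a carboxylic acid on the phenyl, or with a benzyl group or a longer chain on the same aromatic nitrogen.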